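The compounds below may be only part of what the source reports. "The series", "measured", "known", "first", "only" and "open" are said of these compounds alone.

Measured so far in an assay on mitochondria from L6 cells (Rattus norvegicus) for activation, with a stated time of 90 min; on this read-out higher numbers stand for an effect only at larger amounts of compound and lower numbers for an effect already at smaller amounts:
compound 1 `C1CCC(Nc2nc3nonc3nc2NC2CCCC2)C1` gives 45000 nM;
compound 2 `COc1ccc(Nc2nc3nonc3nc2Nc2ccc(OC)cc2)cc1` gives > 100000 nM, which is a limit of the assay and not a number;
compound 3 `Fc1ccccc1Nc1nc2nonc2nc1NC1CCCCC1` gives 13400 nM.

Compound 3 stands lowest of the two numbers; compound 1 sits higher, beyond the usual scatter. Compound 4 `CCOc1cccc(Nc2nc3nonc3nc2Nc2ccccc2F)c1` differs from compound 3 in one place: 3-ethoxyphenyl in place of cyclohexyl on a nitrogen on an aromatic ring. Compound 2 carries an aromatic group on both such nitrogens and reaches only the limit, so a step toward weaker activation is expected, a 3.0-fold higher number from compound 3 to compound 4 (0.47 log units; beyond the scatter), likely beyond the scatter. In this assay compound 4 is expected near 40000 nM, with a range from 12000 nM to 150000 nM; a limit result is possible.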

Compound 4, half-maximal effective concentration: 2200 nM
Beside the measured number, compound 4's estimate is 18-fold (1.26 log units) above it; the measured number lies below the stated range.
By their numbers in this assay, from the lowest: compound 4; then compound 3; then compound 1. At a limit, above all of these: compound 2.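

In this assay, 3-ethoxyphenyl in place of cyclohexyl on this nitrogen gives a 6.1-fold lower number from compound 3 to compound 4 (0.78 log units; beyond the scatter), so at this place an aromatic ring goes with stronger activation, not weaker. Compound 4 thus carries an aromatic group on both such nitrogens and still gives a number. Compound 2 also carries an aromatic group on both and gives > 100000 nM, which is a limit of the assay and not a number, so it goes against any rule that aromatic groups alone set the result. Still open, going by these compounds, is whether the ring or its ethoxy group carries the step. A plain phenyl or a 3-aminophenyl on this nitrogen would separate the two.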